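Taking the chlorines off a thiophene ring

A few compounds are considered here, and "the series" means these few. Any claim that something is new, unique, unknown or untested is made for them only; others in the source may bear on it.

For the measured compounds named here, only two compounds of this family have numbers so far. In a functional assay on cells (Cancer cell lines, Homo sapiens) for inhibition (a higher number here means a weaker inhibitor of growth, a lower number a stronger inhibitor of growth), compound 1 (`N=C(N)N/N=C/c1c(-c2cc(Cl)sc2Cl)nc2n1CCS2`) gives 8710 nM, the higher of the two numbers and so the weaker growth inhibitor. Compound 2 (`Cc1cn2c(/C=N/NC(=N)N)c(-c3cccs3)nc2s1`) gives 4270 nM, a gap just beyond the usual scatter. Compound 2 differs from compound 1 in more than one place, so this pair does not isolate any single change.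

The unmeasured compound 3 (`N=C(N)N/N=C/c1c(-c2ccsc2)nc2n1CCS2`) keeps the core of compound 1 and changes one group: thiophen-3-yl in place of 2,5-dichlorothiophen-3-yl on an aromatic carbon. The ring stays a five-membered aromatic ring, and only the chlorine atoms go. Going by the values given here, no measured pair shows what this change does, so any expectation is loose. Among the compounds with values here, the one hint is that compound 2 carries no chlorine and sits at 4270 nM. In this assay a slight move toward a lower number is therefore expected, probably not beyond the scatter. The expected step of a 1.5-fold lower number from compound 1 to compound 3 (0.16 log units; within the scatter) is small. Compound 3 is estimated at 6000 nM, with an expected range of 2200 nM to 16000 nM.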

Compound 3, concentration for 50% growth inhibition: 25100 nM
For compound 3 the middle estimate is 4.2-fold (0.62 log units) below the measured one; measured number outside the range, above it.
By their numbers in this assay, from the lowest: compound 2; then compound 1; then compound 3.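

Taking the chlorine atoms off the thiophene ring is the first change here that can be read on its own, and in this assay it gives a 2.9-fold higher number from compound 1 to compound 3 (0.46 log units; beyond the scatter) on the shared core, so within this pair the chlorinated compound is the stronger growth inhibitor. The place on the aromatic carbon next to the ring nitrogen is therefore not indifferent to small edits: 2,5-dichlorothiophen-3-yl and thiophen-3-yl keep the same five-membered aromatic ring and differ only in the chlorine atoms, yet the two compounds are separated beyond the usual scatter. No measurement shown here speaks to what lies behind this step.

Going by these compounds, the chlorine atoms leave together in this pair, so it remains open whether a single chlorine on the thiophene ring would keep the stronger growth inhibition of compound 1 or give the weaker one of compound 3. Also open, on these data alone, is how bromine atoms or methyl groups on the same ring, or a phenyl ring in place of the thiophene, would fit into this short series.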